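Amine swaps on the alkoxy side chain of the flavone series

The source may hold more compounds than are shown below. What is called first, only, known or untested is meant among the compounds shown, and "the series" means these compounds.

Three measured compounds share one core and differ only in the basic amine at the end of the alkoxy chain and in the length of that chain. In a functional assay on B16 cells (Mus musculus) for cytotoxicity, read by MTT assay, with a stated time of 72 h (on this read-out lower numbers stand for stronger inhibition and higher numbers for weaker inhibition), compound 1 `CCN(CC)CCCOc1c(OCc2ccccc2)cc(O)c2c(=O)cc(-c3ccccc3)oc12` gives 4900 nM, compound 2 `CN1CCN(CCCOc2c(OCc3ccccc3)cc(O)c3c(=O)cc(-c4ccccc4)oc23)CC1` gives 3760 nM, and compound 3 `CCN(CC)CCCCOc1c(OCc2ccccc2)cc(O)c2c(=O)cc(-c3ccccc3)oc12` gives 4880 nM. Compound 3 thus sits second highest of the three numbers, but every gap to it is inside the scatter: a 1.0-fold lower number from compound 1 to compound 3 (0.00 log units; within the scatter) and a 1.3-fold higher number from compound 2 to compound 3 (0.11 log units; within the scatter).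

Compound 4 `O=c1cc(-c2ccccc2)oc2c(OCCCCN3CCCC3)c(OCc3ccccc3)cc(O)c12` carries the change (pyrrolidin-1-yl in place of diethylamino on a saturated chain carbon, four bonds along the chain from an oxygen on an aromatic ring). Within the data shown here, the steps that bear on such an amine exchange are a 1.3-fold lower number from compound 1 to compound 2 (0.12 log units; within the scatter) and a 1.3-fold higher number from compound 2 to compound 3 (0.11 log units; within the scatter); both exchange one basic amine for another on the same chain and neither moves the number beyond the scatter. The nearest step that alters only the chain length, a 1.0-fold lower number from compound 1 to compound 3 (0.00 log units; within the scatter), is likewise flat. Among the measured compounds shown here, nothing among the measured compounds suggests that a ring closure of the amine should register in this assay.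

Compound 4 is therefore expected to give an estimate of 4800 nM in this assay, with a range from 2400 nM to 9600 nM. The expected step is a 1.0-fold lower number from compound 3 to compound 4 (0.01 log units; within the scatter), that is, no change beyond the scatter.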

Compound 4, half-maximal inhibitory concentration: 3210 nM
Compound 4: the middle estimate sits 1.5-fold (0.17 log units) above what was measured; low and high end bracket the measured number.
By their numbers in this assay, from the lowest: compounds 4, 2, 3 and 1 (each within the scatter of the next).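

In this assay, pyrrolidin-1-yl in place of diethylamino adds one five-membered non-aromatic ring and leaves the number of heavy atoms unchanged, and the step is a 1.5-fold lower number from compound 3 to compound 4 (0.18 log units; within the scatter), so closing the amine into a ring at this place registers no change beyond the scatter. Among these compounds, the two wider comparisons read the same way, with a 1.2-fold lower number from compound 2 to compound 4 (0.07 log units; within the scatter) and a 1.5-fold lower number from compound 1 to compound 4 (0.18 log units; within the scatter), which places the pyrrolidin-1-yl compound in one band with the diethylamino and 4-methylpiperazin-1-yl compounds and leaves no compound among the four apart from the others. No measurement at hand bears on why the number stays flat across these amine exchanges.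

The compounds shown leave open whether this flatness holds for a morpholine, a piperidine or a primary amine at the chain end, or for a chain end with no amine at all, such as a carboxylic acid. As far as these compounds go, a longer or a shorter chain carrying pyrrolidin-1-yl also remains open, so the reach of this tolerance along the chain cannot yet be judged.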